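Pyridinylpiperazine Replaces Tetrahydroisoquinoline at the Chain End

The source may hold more compounds than are shown below. What is called first, only, known or untested is meant among the compounds shown, and "the series" means these compounds.

Compound 1 `COc1cc2c(Nc3ccc(C#N)cc3)ncnc2cc1OCCCN1CCC(CO)CC1` and compound 2 `COc1cc2c(Nc3ccc(C#N)cc3)ncnc2cc1OCCCN1CCc2ccccc2C1` share a core and differ only in the amine at the end of the chain. In a functional assay on HepG2 cells (Homo sapiens) for antiproliferative activity, read by MTT assay, with a stated time of 72 h (on this read-out lower numbers stand for stronger inhibition and higher numbers for weaker inhibition), compound 1 gives 61800 nM. For compound 2 the result in this assay is a limit of the assay, > 100000 nM, so only a bound is known for it; this is the limit of > 100000 nM in this assay, at which 1 of the 2 values shown sits. The step of an at least 1.6-fold higher number from compound 1 to compound 2 (0.20 log units; that floor lies within the scatter) therefore lies within the scatter. Compound 3 `COc1cc2c(Nc3ccc(C#N)cc3)ncnc2cc1OCCCN1CCN(c2ccncc2)CC1` carries 4-(pyridin-4-yl)piperazin-1-yl in place of 1,2,3,4-tetrahydroisoquinolin-2-yl on a saturated chain carbon, three bonds along the chain from an oxygen on an aromatic ring. Among the measured compounds shown here, only one measured step bears on this change, and it reached no further than the scatter, so for compound 3 in this assay no step beyond the scatter is expected in either direction. Compound 3 is therefore expected to give 80000 nM, between 30000 nM and 200000 nM. This estimate implies an at least 1.2-fold lower number from compound 2 to compound 3 (0.09 log units; that floor lies within the scatter), expected to stay close to the limit.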

Compound 3, half-maximal inhibitory concentration: 12600 nM
Compound 3: the middle estimate sits 6.3-fold (0.80 log units) above what was measured, and the stated range ends above it.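

In this assay, the end of the chain proves able to move the read-out beyond the scatter, which the earlier pair could not show: 4-(pyridin-4-yl)piperazin-1-yl in place of 1,2,3,4-tetrahydroisoquinolin-2-yl gives an at least 7.9-fold lower number from compound 2 to compound 3 (0.89 log units; beyond the scatter). The same group in place of 4-(hydroxymethyl)piperidin-1-yl, a pair with two measured values, gives a 4.9-fold lower number from compound 1 to compound 3 (0.69 log units; beyond the scatter). The first of these steps is only a floor because compound 2 stands at a limit of the assay: the limit of > 100000 nM in this assay, at which 1 of the 3 values shown sits.

The compounds shown leave open whether the step belongs to the pyridine ring or to the piperazine ring, a question that a phenylpiperazine or a morpholine at the chain end would help to separate. They also leave open whether the same amine would hold its effect on a shorter or a longer chain.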